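Cytotoxicity notes: the step from compound 3 to compound 4

This account rests on a few compounds, and the source may have more. Where it says the series, first, only, none or still open, it means among the compounds named here.

In an ADME assay on HEp-2 cells (Homo sapiens) for cytotoxicity, read by CCK-8 assay, with a stated time of 6 days (a lower number here means that less compound is tolerated, a higher number that more compound is tolerated), compound 1 `O=c1n(Cc2nc3ccc(C(F)(F)F)cn3c2CCCCO)c2cnccc2n1C1CC1` reaches only the assay limit, reported as > 100000 nM. Compound 2 `O=c1n(Cc2nc3cc(C(F)(F)F)ccn3c2CCCCO)c2cnccc2n1C1CC1` likewise stops at the limit, > 100000 nM. Compound 3 `CS(=O)(=O)CCNC(=O)c1c(Cn2c(=O)n(C3CC3)c3ccncc32)nc2cc(Cl)ccn12` stands at the same limit, > 100000 nM. Every number shown is thus a limit and not a measured value, as noted by the limit of > 100000 nM in this assay, at which 3 of the 3 values shown sit. Within the data shown here, no step between measured compounds exists in this assay. Compound 4 `CS(=O)(=O)c1ccc(-c2c(Cn3c(=O)n(C4CC4)c4ccncc43)nc3cc(Cl)ccn23)cc1` differs from compound 3 in one place: 4-(methylsulfonyl)phenyl in place of (2-(methylsulfonyl)ethyl)carbamoyl on an aromatic carbon. With all three shown values sitting at the limit, no step beyond the scatter in either direction is expected in this assay, and the change is expected to leave compound 4 at the limit too. Compound 4 is therefore estimated at 100000 nM, within 50000 nM to 300000 nM, an expected step of a number no higher from compound 3 to compound 4 (the limit leaves the size open).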

Compound 4, half-maximal cytotoxic concentration: > 100000 nM
Compound 4 ended at the assay's limit; the forecaster's own chance of this, stated with the estimate: 80%; the middle value lies on the limit itself.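

No step can be read between compound 3 and compound 4 in this assay, since both stand at a limit: the limit of > 100000 nM in this assay, at which 4 of the 4 values shown sit.

The compounds shown leave open at what concentration any of them becomes cytotoxic.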